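The source may report more compounds than this note shows. Statements on the series, on what has been measured and on what is new or still open speak of the compounds shown alone.

Measured so far in an ADME assay on MT4 cells (Homo sapiens) for cytotoxicity, read by MTT assay, with a stated time of 4 days; a higher number here means that more compound is tolerated, a lower number that less compound is tolerated: compound 1 `O=C(COc1cccc2ccccc12)N/N=C/c1ccc(Cl)cc1` gives 87.6 ug/mL; compound 2 `O=C(COc1cccc2ccccc12)N/N=C/c1ccccc1Br` gives 11.4 ug/mL; compound 3 `O=C(COc1cccc2ccccc12)N/N=C/C=C/c1ccccc1` gives 82.7 ug/mL.

Compound 3 stands second highest of the three numbers in this assay, within the scatter of compound 1, and well apart from compound 2, as the step of a 7.3-fold higher number from compound 2 to compound 3 (0.86 log units; beyond the scatter) shows. Compound 4 `O=C(COc1cccc2ccccc12)N/N=C/c1ccccc1O` differs from compound 3 by 2-hydroxyphenyl in place of 2-phenylethenyl on a carbon with a double bond to nitrogen. Within the data shown here, no measured step makes this exchange. As far as these compounds go, the steps at the same carbon were a 1.1-fold lower number from compound 1 to compound 3 (0.02 log units; within the scatter) and a 7.7-fold lower number from compound 1 to compound 2 (0.89 log units; beyond the scatter), so only the entry of 2-bromophenyl moved the number, while the hydroxy case is untested. A downward step of intermediate size is therefore expected for compound 4 in this assay, a 1.8-fold lower number from compound 3 to compound 4 (0.26 log units; within the scatter). The estimate for compound 4 is 45 ug/mL, with a range from 10 ug/mL to 120 ug/mL.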

Compound 4, half-maximal cytotoxic concentration: 5.19 ug/mL
Estimate against measurement, compound 4: 8.7-fold (0.94 log units) above, and the stated range ends above it.
By their numbers in this assay, from the lowest: compound 4; then compound 2; then compounds 3 and 1 (each within the scatter of the next).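

In this assay, 2-hydroxyphenyl on the carbon with a double bond to nitrogen gives a 16-fold lower number from compound 3 to compound 4 (1.20 log units; beyond the scatter) and a 17-fold lower number from compound 1 to compound 4 (1.23 log units; beyond the scatter), larger drops than 2-bromophenyl gave at this place. Hydroxy in place of bromo on the aromatic carbon gives a 2.2-fold lower number from compound 2 to compound 4 (0.34 log units; beyond the scatter) and so moves the number further, which shows that low numbers here are not confined to bromo. Nothing measured on these compounds speaks to the reason for these steps.

Open, as far as these compounds go, is whether methoxy or an amine on that aromatic carbon would give a number like that of compound 4 or like that of compound 1.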